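The compounds below may be only part of what the source reports. "The series", "measured", "known", "first", "only" and "open" are said of these compounds alone.

Among the measured compounds shown here, of the two compounds measured so far in a physicochemical assay for solubility, measured as kinetic solubility, with a stated time of 1 h, at pH 7.4 (a lower number here means a less soluble compound, a higher number a more soluble compound), compound 2 `O=C(NC1=NN(c2ccc(Cl)c(Cl)c2)CC1)c1cccnn1` has the higher number. Compound 1 `CC(=O)NC1=NN(c2ccc(Cl)c(Cl)c2)CC1` gives 31000 nM, while compound 2 gives 67000 nM. The next compound, compound 3 `O=C(NC1=NN(c2ccc(Cl)c(Cl)c2)CC1)c1ccnnc1`, keeps the shared core and the amide-type nitrogen and differs only in the ring on the carbonyl carbon: pyridazin-4-yl in place of pyridazin-3-yl on a carbonyl carbon. Put simply, pyridazin-4-yl takes the place of pyridazin-3-yl, and the two groups have the same atoms, joined differently.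

For the measured compounds named here, only one measured step bears on this change: a 2.2-fold higher number from compound 1 to compound 2 (0.33 log units; beyond the scatter). That step is modest, though beyond the usual scatter, and it replaced a methyl with a whole pyridazin-3-yl ring. Going by the values given here, the change to compound 3 is a swap of one pyridazinyl group for another, and no measured pair shows what such a swap does. The expectation is therefore no step beyond the scatter, in either direction. The expected change is a 1.0-fold higher number from compound 2 to compound 3 (0.02 log units; within the scatter). For compound 3, the estimated value is 70000 nM, with an expected range from 35000 nM to 140000 nM.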

Compound 3, solubility: 23000 nM
Compound 3: the middle estimate sits 3.0-fold (0.48 log units) above what was measured, outside the stated range (below it).
By their numbers in this assay, from the lowest: compounds 3 and 1 (each within the scatter of the next); then compound 2.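

At this place, on a carbonyl carbon whose other neighbour is the amide-type nitrogen, the same atoms joined differently do not give the same result in this assay: the change shows a 2.9-fold lower number from compound 2 to compound 3 (0.46 log units; beyond the scatter), a modest step that lies beyond the scatter. Putting a pyridazinyl ring in place of methyl also does not raise the number in every case, since pyridazin-3-yl gave a 2.2-fold higher number from compound 1 to compound 2 (0.33 log units; beyond the scatter), whereas pyridazin-4-yl gave a 1.3-fold lower number from compound 1 to compound 3 (0.13 log units; within the scatter), which lies within the scatter. Nothing available here explains why the two pyridazinyl groups differ in this way.

The compounds shown carry only methyl, pyridazin-3-yl and pyridazin-4-yl at this place, so it remains open where a phenyl ring, a pyridin-3-yl ring, an amine or a longer chain would fall on this scale. Going by these compounds, it is also open whether the gap between the two pyridazinyl groups would hold if the shared core were changed elsewhere.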